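The source may report more compounds than this note shows. Statements on the series, on what has been measured and on what is new or still open speak of the compounds shown alone.

Measured in a functional assay on a cell-free system (plasma, Homo sapiens), with a stated time of 3 min; on this read-out lower numbers stand for stronger inhibition and higher numbers for weaker inhibition: compound 1 `COC(C)(C)[C@@H](O)C(=O)N1N=CC[C@H]1C(=O)NCc1cc(Cl)ccc1-n1cnnn1` gives 3700 nM; compound 2 `CC1(C[C@@H](O)C(=O)N2N=CC[C@H]2C(=O)NCc2cc(Cl)ccc2-n2cnnn2)CC1` gives 730 nM; compound 3 `O=C(NCc1cc(Cl)ccc1-n1cnnn1)[C@@H]1CC=NN1C(=O)[C@H](O)c1ccccc1F` gives 1100 nM.

Compound 3 stands second highest of the three numbers: compound 1 lies a step away, a 3.4-fold lower number from compound 1 to compound 3 (0.53 log units; beyond the scatter), while compound 2 sits within the scatter of it, a 1.5-fold higher number from compound 2 to compound 3 (0.18 log units; within the scatter). Compound 4 `CC(C)(C)C[C@@H](O)C(=O)N1N=CC[C@H]1C(=O)NCc1cc(Cl)ccc1-n1cnnn1` differs from compound 3 by neopentyl in place of 2-fluorophenyl on a saturated chain carbon bound to a carbonyl carbon and an oxygen on a saturated carbon. For the measured compounds named here, the steps that bear on this are the two from compound 1, a 5.1-fold lower number from compound 1 to compound 2 (0.70 log units; beyond the scatter) and a 3.4-fold lower number from compound 1 to compound 3 (0.53 log units; beyond the scatter), which brought a branched saturated chain and the fluorinated ring to nearly the same place. Neopentyl resembles (1-methylcyclopropyl)methyl more than it does 2-fluorophenyl, so since compound 2 gives 730 nM, compound 4 is expected to show a step of a 1.5-fold lower number from compound 3 to compound 4 (0.17 log units; within the scatter), within the scatter. The estimate for compound 4 in this assay is 750 nM, range 250 nM to 2200 nM.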

Compound 4, half-maximal inhibitory concentration: 590 nM
Compound 4: the middle estimate sits 1.3-fold (0.10 log units) above what was measured, within the range that was stated.
By their numbers in this assay, from the lowest: compounds 4, 2 and 3 (each within the scatter of the next); then compound 1.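

In (this assay) the position accepts neopentyl, which has no ring, as readily as the 2-fluorophenyl ring (a 1.9-fold lower number from compound 3 to compound 4 (0.27 log units; within the scatter)), and tert-butyl cannot be told apart from 1-methylcyclopropyl at the chain end (a 1.2-fold lower number from compound 2 to compound 4 (0.09 log units; within the scatter)). Among the compounds shown, the separation remains with compound 1 and its 1-methoxy-1-methylethyl group (a 6.3-fold lower number from compound 1 to compound 4 (0.80 log units; beyond the scatter)), a step beyond the scatter. Nothing at hand explains these steps. Going by these compounds, whether an amine, a carboxylic acid or a longer chain at this carbon would fall with compound 1 or with the other three remains open.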